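Compound 3: the ether side chain removed

The source may hold more compounds than are shown below. What is called first, only, known or untested is meant among the compounds shown, and "the series" means these compounds.

Compound 1, `O=c1c(Cc2coc3cccc(OCC4CCCCC4)c3c2=O)coc2ccccc12`, gives 3530 nM in a functional assay on NUGC-3 cells (Homo sapiens) for antiproliferative activity, read by XTT assay; a higher number here means a weaker inhibitor, a lower number a stronger inhibitor.
Compound 2, `CC(C)CCOc1cccc2occ(Cc3coc4ccccc4c3=O)c(=O)c12`, reaches only the assay limit of > 10000 nM in this assay.

Compound 2 thus stands at the weak end of the two values shown, with a limit rather than a number, as noted in the limit of > 10000 nM in this assay, at which 1 of the 2 values shown sits. Compound 3, `O=c1c(Cc2coc3ccccc3c2=O)coc2ccccc12`, differs from compound 2 by hydrogen in place of isopentyloxy on an aromatic carbon. Among the compounds with values here, the only measured step that bears on this change is an at least 2.8-fold higher number from compound 1 to compound 2 (0.45 log units; beyond the scatter), which ran in the weakening direction; no measured pair removes the chain outright, so the direction for compound 3 remains open. Compound 3 is expected near 9000 nM, within 2500 nM to 30000 nM, the expected step being an at least 1.1-fold lower number from compound 2 to compound 3 (0.04 log units; that floor lies within the scatter).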

Compound 3, half-maximal inhibitory concentration: 7770 nM
Compound 3: middle estimate off by 1.2-fold (0.06 log units), on the high side, within the range that was stated.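

Removing cyclohexylmethoxy from this aromatic carbon gives a 2.2-fold higher number from compound 1 to compound 3 (0.34 log units; beyond the scatter) in this assay, so that ether chain goes with a stronger result than hydrogen. Removing isopentyloxy gives an at least 1.2-fold lower number from compound 2 to compound 3 (0.10 log units; that floor lies within the scatter), so this chain shows no gain over hydrogen, and an ether at this carbon does not by itself strengthen the result. Compound 2 carries only a limit, which leaves the size of that step unsettled: the limit of > 10000 nM in this assay, at which 1 of the 3 values shown sits.

From the compounds shown here alone, whether a hydroxy group, an amine or a benzyloxy group at this carbon would match cyclohexylmethoxy remains open.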